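Phenyl for Cyclohexyl on the Iodo Analogue, Compound 4

The source may report more compounds than this note shows. Statements on the series, on what has been measured and on what is new or still open speak of the compounds shown alone.

Compound 3 `Oc1nc(NCC2CCCCC2)nc2ccc(I)cc12` gives 97.9% in a functional assay on the whole organism (uterus) with Rattus norvegicus as the target, tested at 50 uM; a lower number here means a stronger effect, a higher number a weaker effect of the compound at the concentration tested. Among the three numbers so far it stands second highest; compound 2 `Oc1nc(NCc2ccccc2)nc2ccc(Cl)cc12` with 98.1% lies within the scatter of it, while compound 1 `Oc1nc(NCC2CCCCC2)nc2ccc(Cl)cc12` with 80.3% sits beyond the scatter below it, as the step of a number 17.6 percentage points higher from compound 1 to compound 3 (beyond the scatter) shows. Compound 4 `Oc1nc(NCc2ccccc2)nc2ccc(I)cc12` differs from compound 3 in one place: phenyl in place of cyclohexyl on a saturated chain carbon bound to a nitrogen on an aromatic ring. The same exchange has been measured once, on the chloro pair, where a number 17.8 percentage points higher from compound 1 to compound 2 (beyond the scatter). That step was modest, yet compound 3 already sits close to the upper end of what this read-out can show, so little room remains for a further rise, and a change that stays within the scatter is expected. Compound 4 is therefore estimated at 99% with a range of 91% to 105%. The expected step of a number 1.1 percentage points higher from compound 3 to compound 4 (within the scatter) is judged not to lie beyond the scatter.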

Compound 4, a percentage reported as activity, at one concentration (the size of the read-out at that concentration, not a potency): 106%
The estimate for compound 4 lay 7 percentage points below the measured number; measured number outside the range, above it.
By their numbers in this assay, from the lowest: compound 1; then compounds 3, 2 and 4 (each within the scatter of the next).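

Phenyl in place of cyclohexyl gives a number 8.1 percentage points higher from compound 3 to compound 4 (within the scatter) on the iodo core, which shows the exchange staying within the scatter here, though the two measurements of it cannot be told apart: the same change on two cores in this assay, a number 17.8 percentage points higher (beyond the scatter) from compound 1 to compound 2 and a number 8.1 percentage points higher (within the scatter) from compound 3 to compound 4, 9.7 percentage points apart, within the scatter of two such steps. The second pair adds the same reading for the halogen, with iodo in place of chloro giving a number 7.9 percentage points higher from compound 2 to compound 4 (within the scatter) when phenyl is present: the same change on two cores in this assay, a number 17.6 percentage points higher (beyond the scatter) from compound 1 to compound 3 and a number 7.9 percentage points higher (within the scatter) from compound 2 to compound 4, 9.7 percentage points apart, within the scatter of two such steps. Only compound 1, which joins cyclohexyl to chloro, stands apart from its two one-change neighbours, while the steps now measured away from those neighbours stay within the scatter.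

Going by these compounds, whether fluoro or bromo in place of chloro would keep the lower number of compound 1 remains open. So does the effect of a longer chain carrying the cyclohexyl, or of an amine on that ring.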